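Benzothiazole oxamates: swapping the indole amide for pyrimidine

This account rests on a few compounds, and the source may have more. Where it says the series, first, only, none or still open, it means among the compounds named here.

Measured in a functional assay on SK-BR-3 cells (Homo sapiens) for antiproliferative activity; on this read-out higher numbers stand for an effect only at larger amounts of compound and lower numbers for an effect already at smaller amounts:
compound 1 `CCOC(=O)C(=O)Nc1nc2ccc(NC(=O)c3ccccc3)cc2s1` gives 9730 nM
compound 2 `CCOC(=O)C(=O)Nc1ccc2nc(NC(=O)c3cc4cc(C)ccc4[nH]3)sc2c1` gives 2810 nM
compound 3 `CCOC(=O)C(=O)Nc1ccc2nc(NC(=O)c3cc4cc(CC)ccc4[nH]3)sc2c1` gives 20600 nM

Among the compounds with values here, compound 2 holds the lowest number of the three in this assay; compound 1 sits at a higher number, and the one measured single-point step, a 7.3-fold higher number from compound 2 to compound 3 (0.87 log units; beyond the scatter), moves away from compound 2 as well. Compound 4 `CCOC(=O)C(=O)Nc1ccc2nc(NC(=O)c3ncccn3)sc2c1` arises from compound 2 by pyrimidin-2-yl in place of 5-methyl-1H-indol-2-yl on a carbonyl carbon. Within the data shown here, no measured pair shows this exact exchange. The step from compound 2 to compound 3 shows only that a small addition on the indole already costs a modest amount, and compound 1, which carries a plain benzamide on the shared core, gives a higher number than compound 2. Both observations point to the indole amide of compound 2 being favourable, so its replacement by the smaller pyrimidin-2-yl is expected to raise the number: the estimated step is a 4.3-fold higher number from compound 2 to compound 4 (0.63 log units; beyond the scatter). Compound 4 is therefore expected to give about 12000 nM in this assay, with a range from 4000 nM to 40000 nM.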

Compound 4, half-maximal effective concentration: > 50000 nM
Compound 4: no number, only a limit (the forecaster's own chance of this, stated with the estimate: 20%); at least 4.1-fold (0.61 log units) between middle value and limit.
By their numbers in this assay, from the lowest: compound 2; then compound 1; then compound 3. At a limit, above all of these: compound 4.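

In this assay compound 4 gives > 50000 nM, which is a limit of the assay and not a number. Replacing the whole 5-methyl-1H-indol-2-yl on the carbonyl carbon, rather than only extending it as in a 7.3-fold higher number from compound 2 to compound 3 (0.87 log units; beyond the scatter), shows that this position does not accept pyrimidin-2-yl in place of the indole, with an at least 17-fold higher number from compound 2 to compound 4 (1.25 log units; beyond the scatter). The step is a lower bound, and its real size stays unknown: the limit of > 50000 nM in this assay, at which 1 of the 4 values shown sits.

The exchange removes the indole's five-membered ring and its hydrogen-bond donor and brings in two ring nitrogens all at once, and the compounds shown cannot separate these changes. From the compounds shown here alone, how an unsubstituted 1H-indol-2-yl, a pyridin-2-yl or a pyrimidine carrying an amine would behave on this carbonyl carbon remains open.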